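The source may report more compounds than this note shows. Statements on the series, on what has been measured and on what is new or still open speak of the compounds shown alone.

Measured so far:
Compound 1 `C=CC(=O)Nc1cccc(Oc2nc(Nc3ccn(C)n3)nc3c2CSCC3)c1`: 25800 nM
Compound 2 `CC(C)/C=C/C(=O)Nc1cccc(Oc2nc(Nc3ccn(C)n3)nc3c2CSCC3)c1`: 40100 nM

In a functional assay on HeLa cells (Homo sapiens) for antiproliferative activity, read by MTT assay, with a stated time of 72 h (a lower number here means a stronger inhibitor, a higher number a weaker inhibitor), compound 2 gives 40100 nM and sits level with compound 1 within the scatter, as a 1.6-fold higher number from compound 1 to compound 2 (0.19 log units; within the scatter) shows. Both compounds are only two points, so this places compound 2 in a narrow and thinly sampled range.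

Compound 3 `C=C(F)C(=O)Nc1cccc(Oc2nc(Nc3ccn(C)n3)nc3c2CSCC3)c1` carries 1-fluoroethenyl in place of 3-methylbut-1-en-1-yl on a carbonyl carbon. Going by the values given here, the only measured step at this carbonyl carbon is a 1.6-fold higher number from compound 1 to compound 2 (0.19 log units; within the scatter), and it stays small. Among the compounds with values here, no measured step covers 1-fluoroethenyl itself, so the expectation rests on that single step and remains loose.

In this assay no change beyond the scatter is expected, and the estimated step is a 1.4-fold lower number from compound 2 to compound 3 (0.16 log units; within the scatter). The estimated value for compound 3 is 28000 nM, with an expected range of 11000 nM to 65000 nM.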

Compound 3, half-maximal inhibitory concentration: > 50000 nM
Compound 3: only a limit was reported; the forecaster's own chance of this, stated with the estimate: 10%; middle value at least 1.7-fold (0.25 log units) away from the limit.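

Compound 3 gives > 50000 nM in this assay, which is a limit of the assay and not a number. Read as floors, an at least 1.2-fold higher number from compound 2 to compound 3 (0.09 log units; that floor lies within the scatter) and an at least 1.9-fold higher number from compound 1 to compound 3 (0.28 log units; that floor lies within the scatter), so neither fluoro in place of hydrogen on the double-bonded chain carbon nor 1-fluoroethenyl in place of 3-methylbut-1-en-1-yl is shown to move the read-out beyond the scatter, while the true size of either step remains unbounded on the upper side. Unlike the earlier pair, the series at this carbonyl carbon now meets a limit: the limit of > 50000 nM in this assay, at which 1 of the 3 values shown sits.

Going by these compounds, the size of the fluoro step remains open until a value replaces the limit. Also open, on these data alone, is how the read-out responds at this carbonyl carbon to a saturated ethyl chain or to a chain bearing a dimethylamino group.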